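A few compounds are considered here, and "the series" means these few. Any claim that something is new, unique, unknown or untested is made for them only; others in the source may bear on it.

Compound 1 `O=S(=O)(/C=C/c1ccc(Cl)nc1)c1cccc(F)c1`: in an assay on U2OS cells for activation of nuclear factor erythroid 2-related factor 2 (Homo sapiens), read by beta-arrestin recruitment, with a stated time of 6 h (on this read-out higher numbers stand for an effect only at larger amounts of compound and lower numbers for an effect already at smaller amounts), compound 1 gives 4870 nM.
Compound 2 `O=S(=O)(/C=C/c1cccnc1)c1cccc(Cl)c1`: in this assay compound 2 gives 3520 nM.

Compound 2 sits closest to compound 1 among the two numbers shown, and the gap between them lies within the scatter, so neither compound stands apart from the other. The unmeasured compound 3 `O=S(=O)(/C=C/c1ccc(Cl)nc1)c1cccc(Cl)c1` differs from compound 2 by chloro in place of hydrogen on an aromatic carbon. Among the measured compounds shown here, no step between two measured compounds bears on this change, so the expected step of a 1.2-fold higher number from compound 2 to compound 3 (0.08 log units; within the scatter) is taken as none beyond the scatter. On that basis compound 3 is expected to give 4200 nM in this assay, within a range from 1800 nM to 9500 nM.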

Compound 3, half-maximal effective concentration: 2210 nM
Compound 3: the middle estimate sits 1.9-fold (0.28 log units) above what was measured; measured number inside the range.
By their numbers in this assay, from the lowest: compounds 3, 2 and 1 (each within the scatter of the next, the first and the last beyond it).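

In this assay, chloro in place of hydrogen next to the ring nitrogen gives a 1.6-fold lower number from compound 2 to compound 3 (0.20 log units; within the scatter) and so leaves the number within the scatter at this position. Chloro in place of fluoro on an aromatic carbon gives a 2.2-fold lower number from compound 1 to compound 3 (0.34 log units; beyond the scatter) and is the only single change here that reaches beyond the scatter, though only modestly. Nothing at hand accounts for either step. 

The compounds shown leave open how an amine, a methoxy group or a carboxylic acid next to the ring nitrogen would read. They also leave open whether bromo would follow chloro at either place.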